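A few compounds are considered here, and "the series" means these few. Any claim that something is new, unique, unknown or untested is made for them only; others in the source may bear on it.

Measured in a physicochemical assay for solubility, using the shake flask method, in simulated intestinal fluid, measured as kinetic solubility, with a stated time of 20 h, at pH 6.5; a higher number here means a more soluble compound, a lower number a less soluble compound:
- Compound 1 `Fc1ccc(-c2nc3cnc(Nc4ccc(C(F)(F)F)cn4)cc3[nH]2)cc1F`: >= 50000 nM
- Compound 2 `FC(F)(F)c1ccc(Nc2cc3[nH]c(C4CCCC4)nc3cn2)nc1`: 85000 nM

Among the compounds with values here, compound 2 stands at 85000 nM, the only actual number so far. Compound 1 gives >= 50000 nM, which is a limit of the assay and not a number.

Compound 3 `FC1(F)CCC(c2nc3cnc(Nc4ccc(C(F)(F)F)cn4)cc3[nH]2)C1` puts 3,3-difluorocyclopentyl in place of cyclopentyl on an aromatic carbon. Within the data shown here, the one measured step at this place is a step that the limit leaves unreadable from compound 1 to compound 2. It offers no size to carry over because of the limit of >= 50000 nM in this assay, at which 1 of the 2 values shown sits. No step beyond the usual scatter is therefore expected in this assay, and the expected step is a 1.4-fold lower number from compound 2 to compound 3 (0.15 log units; within the scatter). For compound 3 the estimate is 60000 nM, with an expected range from 25000 nM to 120000 nM.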

Compound 3, solubility: 163000 nM
The estimate for compound 3 lay 2.7-fold (0.43 log units) below the measured number; measured number outside the range, above it.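

This position now has its first readable step in this assay: a 1.9-fold higher number from compound 2 to compound 3 (0.28 log units; within the scatter). The two fluorine atoms added to the cyclopentyl ring therefore make no difference that this measurement can separate from repeat-to-repeat variation. The steps starting from compound 1 cannot be read, because they rest on a limit and not a number: the limit of >= 50000 nM in this assay, at which 1 of the 3 values shown sits.

The compounds shown leave open how this position responds to a group of a different kind, such as an amine or a carboxylic acid on the five-membered ring, and whether such a group would produce a step beyond the scatter.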